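Working notes: from compound 2 to compound 3

A few compounds are considered here, and "the series" means these few. Any claim that something is new, unique, unknown or untested is made for them only; others in the source may bear on it.

In an ADME assay for permeability, using PAMPA, with a stated time of 4 h, at pH 7.4 (a higher number here means that the compound crosses the layer faster, a lower number that the compound crosses the layer more slowly), compound 1 (`CN1CCN(Nc2cccc3c2C[C@@H](CN(C)[C@H]2CCCc4cccnc42)NC3)CC1`) gives 235 nm/s and compound 2 (`CN(C)C1CCN(c2cccc3c2C[C@H](CN(C)[C@H]2CCCc4cccnc42)NC3)CC1`) gives 44 nm/s as the lower of the two numbers. The gap between them lies beyond the usual scatter. Among the compounds with values here, these two compounds differ in more than one place, so their gap offers no single step to carry forward.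

Compound 3 (`CN1C[C@@H]2CN(c3cccc4c3C[C@H](CN(C)[C@H]3CCCc5cccnc53)NC4)C[C@@H]2C1`) keeps the core of compound 2 and changes one group on an aromatic carbon (a group of 9 heavy atoms (7 carbon, 2 nitrogen; 2 five-membered non-aromatic rings with 1 hetero atom each) in place of a group of 9 heavy atoms (7 carbon, 2 nitrogen; one six-membered non-aromatic ring with 1 hetero atom), on an aromatic carbon) with the rest of the structure left as it stands. A six-membered non-aromatic ring gives way to two five-membered non-aromatic rings, while the counts of heavy atoms, donors and acceptors stay level. Within the data shown here, no measured pair shows this kind of exchange, so the expectation rests on the structural change alone. No step beyond the scatter is expected in this assay and no direction is favoured. The estimated step of a 1.0-fold higher number from compound 2 to compound 3 (0.01 log units; within the scatter) is expected to stay within the scatter. Compound 3 is estimated at 45 nm/s with an expected range of 18 nm/s to 110 nm/s for the measurement.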

Compound 3, apparent permeability: 5 nm/s
Compound 3: the middle estimate sits 9.0-fold (0.95 log units) above what was measured, and the stated range ends above it.
By their numbers in this assay, from the lowest: compound 3; then compound 2; then compound 1.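

In this assay, putting the group with 2 five-membered non-aromatic rings in place of 4-(dimethylamino)piperidin-1-yl gives an 8.8-fold lower number from compound 2 to compound 3 (0.94 log units; beyond the scatter). Within the data shown here, this is the first step that can be read at a single place, and it shows that this aromatic carbon, ortho to a fused ring, is not indifferent to which of these two groups it carries. Equal counts of heavy atoms, hydrogen-bond donors and hydrogen-bond acceptors therefore do not make these two groups interchangeable in this read-out, and no measurement at hand accounts for the size of the step.

The compounds shown do not separate the change from one six-membered ring to two five-membered rings from the presence of 2 defined stereocentres in the entering group. They also leave open how this assay would read for the same core carrying a morpholine or a primary amine on this aromatic carbon, which would show whether the step belongs to this one pair of groups or extends further.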